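The source may report more compounds than this note shows. Statements on the series, on what has been measured and on what is new or still open speak of the compounds shown alone.

Measured so far in a functional assay on MCF7 cells (Homo sapiens) for inhibition, read by radiometric assay and XTT assay; on this read-out higher numbers stand for weaker inhibition and lower numbers for stronger inhibition
compound 1 `CCCCCCCC[C@@]1(C)SC(=O)C=C1OCC(=O)OCC` gives 35.3 ug/mL
compound 2 `C=CCC1(CC=C)C(=O)S[C@](C)(CCCCCCCC)C1=O` gives 40.5 ug/mL
compound 3 `C=CCNC(=O)COC1=CC(=O)S[C@]1(C)CCCCCCCC` gives 12.1 ug/mL

Of these three, compound 3 at 12.1 ug/mL has the lowest number, and compound 1 and compound 2 both stand higher, beyond the scatter. Next comes compound 4 `CCCCCCCC[C@@]1(C)SC(=O)C=C1OC(=O)OCC`, not yet measured. The structural change from compound 3 is ethoxycarbonyl in place of (allylcarbamoyl)methyl on an oxygen on an unsaturated carbon and in words it is ethoxycarbonyl in place of (allylcarbamoyl)methyl on an oxygen on an unsaturated carbon. The allylamino group is lost and an ethoxy group on a carbonyl carbon comes in.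

Among the measured compounds shown here, only one measured step bears on this. It is a 2.9-fold lower number from compound 1 to compound 3 (0.46 log units; beyond the scatter) with allylamino in place of ethoxy on a carbonyl carbon, a modest step beyond the scatter. For the measured compounds named here, compound 4 undoes that exchange only in part, since ethoxycarbonyl is not the group carried by compound 1, and no measured compound carries it. A modest move to a higher number, of similar size to that step, is expected in this assay and would mean weaker inhibition. The expected step is a 2.3-fold higher number from compound 3 to compound 4 (0.36 log units; beyond the scatter) and it remains uncertain. Compound 4 is estimated at 28 ug/mL with an expected range of 13 ug/mL to 60 ug/mL in this read-out.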

Compound 4, half-maximal inhibitory concentration: 15.1 ug/mL
Compound 4: the middle estimate sits 1.9-fold (0.27 log units) above what was measured; measured number inside the range.
By their numbers in this assay, from the lowest: compounds 3 and 4 (each within the scatter of the next); then compounds 1 and 2 (each within the scatter of the next).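

In this assay the change at the oxygen on an unsaturated carbon gives a 1.2-fold higher number from compound 3 to compound 4 (0.10 log units; within the scatter) and so leaves the number level, although ethoxycarbonyl carries no hydrogen-bond donor and the allylamino group of compound 3 is gone. Taking away the methylene of (ethoxycarbonyl)methyl gives a 2.3-fold lower number from compound 1 to compound 4 (0.37 log units; beyond the scatter) and brings the number into line with that of compound 3, so at this position a low number does not depend on the allylamino group and an ethoxy group does not by itself go with the higher number of compound 1. Nothing in hand accounts for either step.

Going by these compounds, what remains open is how far this tolerance at the oxygen extends, for instance to a free carboxylic acid, an acetyl group, a benzyloxycarbonyl group or a tertiary amide such as a dimethylamide. On these data alone, it is also open whether the two low numbers hold when the ethoxy of ethoxycarbonyl gives way to an amine, which would form a carbamate, or when a shorter chain replaces the long alkyl chain on the core.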